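The source may report more compounds than this note shows. Statements on the series, on what has been measured and on what is new or still open speak of the compounds shown alone.

Within the data shown here, compound 2 `Cc1cc(O)c(C2=NN(c3ccc(S(N)(=O)=O)cc3)C(c3ccccc3Cl)C2)cc1Cl` holds the lowest of the two numbers so far in a functional assay on MDA-MB-231 cells (Homo sapiens) for antiproliferative activity, with a stated time of 48 h; on this read-out higher numbers stand for lower toxicity in this test and lower numbers for higher toxicity in this test. In this assay, among the measured compounds shown here, compound 1 `Cc1cc(O)c(C2=NN(c3ccc(S(N)(=O)=O)cc3)C(c3ccccc3O)C2)cc1Cl` gives 29500 nM, while compound 2 gives 9520 nM; the single measured step, a 3.1-fold lower number from compound 1 to compound 2 (0.49 log units; beyond the scatter), comes from chloro in place of hydroxy on an aromatic carbon. Compound 3 `Cc1cc(O)c(C2=NN(c3ccc(S(N)(=O)=O)cc3)C(/C=C/c3ccccc3)C2)cc1Cl` differs from compound 2 by 2-phenylethenyl in place of 2-chlorophenyl on a saturated ring carbon. For the measured compounds named here, no measured step covers this exact exchange; the one step on record, a 3.1-fold lower number from compound 1 to compound 2 (0.49 log units; beyond the scatter), only shows that altering the group on that saturated ring carbon can move the number beyond the scatter, and its direction cannot be carried over to a change in which the whole 2-chlorophenyl leaves. The expectation is therefore a step of unclear direction, most likely modest, and it is estimated as a 1.6-fold higher number from compound 2 to compound 3 (0.20 log units; within the scatter). For compound 3 the number in this assay is estimated at 15000 nM, within a range from 4500 nM to 50000 nM.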

Compound 3, concentration lethal to 50% of the cells: 40800 nM
Compound 3: the middle estimate sits 2.7-fold (0.43 log units) below what was measured; the range from low to high includes it.
By their numbers in this assay, from the lowest: compound 2; then compounds 1 and 3 (each within the scatter of the next).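

In this assay, the exchange of 2-chlorophenyl for 2-phenylethenyl on the saturated ring carbon gives a 4.3-fold higher number from compound 2 to compound 3 (0.63 log units; beyond the scatter), so this position also responds when the whole group is replaced, not only when the substituent on its aromatic ring changes. The same 2-phenylethenyl in place of 2-hydroxyphenyl gives a 1.4-fold higher number from compound 1 to compound 3 (0.14 log units; within the scatter), which leaves compound 2, with its 2-chlorophenyl, as the only one of the three set apart at this position. Nothing available explains why the number moves with these groups.

The compounds shown leave open whether the double bond of 2-phenylethenyl matters, which a saturated 2-phenylethyl chain at this carbon would test. They also leave open how a 2-aminophenyl or a 2-fluorophenyl group would compare with 2-chlorophenyl here.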